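Swapping the benzyl group on a sulfonyl urea core

This account rests on a few compounds, and the source may have more. Where it says the series, first, only, none or still open, it means among the compounds named here.

Measured so far in an assay on isolated protein for displacement of a labelled ligand from Orexin/Hypocretin receptor type 1 (Homo sapiens), with a stated time of 90 min; on this read-out lower numbers stand for stronger inhibition and higher numbers for weaker inhibition:
compound 1 `COc1ccc(N2C(=O)N(Cc3c(F)cc(F)cc3F)c3ccccc3S2(=O)=O)cc1OC` gives 50.1 nM
compound 2 `COc1ccc(N2C(=O)N(Cc3ccc(F)cc3Cl)c3ccccc3S2(=O)=O)cc1OC` gives > 2510 nM
compound 3 `COc1cc(F)c(CN2C(=O)N(c3ccc(OC)c(OC)c3)S(=O)(=O)c3ccccc32)c(F)c1` gives 2 nM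

Compound 2 does not give a number but a limit of this assay, (the limit of > 2510 nM in this assay, at which 1 of the 3 values shown sits). Among the numbers shown, compound 1 stands highest; compound 3 sits a long way below it, a 25-fold lower number from compound 1 to compound 3 (1.40 log units; beyond the scatter).

The untested compound 4 `COc1ccc(N2C(=O)N(Cc3c(F)cc(C)cc3Cl)c3ccccc3S2(=O)=O)cc1OC` differs from compound 1 in one place: 2-chloro-6-fluoro-4-methylphenyl in place of 2,4,6-trifluorophenyl on a saturated chain carbon bound to an amide-type nitrogen in a ring.

Within the data shown here, two measured steps bear on this. Replacing the same group by 2-chloro-4-fluorophenyl cost heavily, an at least 50-fold higher number from compound 1 to compound 2 (1.69 log units; beyond the scatter), while replacing one fluoro by methoxy on the aromatic carbon gained strongly, a 25-fold lower number from compound 1 to compound 3 (1.40 log units; beyond the scatter). The entering 2-chloro-6-fluoro-4-methylphenyl resembles the 2,6-difluoro-4-methoxyphenyl of compound 3 more closely than the 2-chloro-4-fluorophenyl of compound 2, and the methyl occupies the place where compound 3 carries methoxy. The exchange of fluoro for chloro has no direct counterpart among these three compounds, so its effect is uncertain. A moderate gain in this assay is therefore expected, smaller than the step seen for compound 3, a 3.3-fold lower number from compound 1 to compound 4 (0.52 log units; beyond the scatter). Compound 4 is estimated at 15 nM, within a range of 3 nM to 80 nM.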

Compound 4, inhibition constant: 6.31 nM
Beside the measured number, compound 4's estimate is 2.4-fold (0.38 log units) above it; low and high end bracket the measured number.
By their numbers in this assay, from the lowest: compound 3; then compound 4; then compound 1. At a limit, above all of these: compound 2.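

Compound 2 had put a chloro-bearing benzyl group at the weak end, yet in this assay another chloro-bearing group improves on the 2,4,6-trifluorophenyl, giving a 7.9-fold lower number from compound 1 to compound 4 (0.90 log units; beyond the scatter), so chloro in this group does not by itself spoil the result. Between the two chloro-bearing groups the difference is far larger, at an at least 390-fold lower number from compound 2 to compound 4 (2.59 log units; beyond the scatter), which shows how much depends on what else the ring carries, and this step rests on a limit rather than a number: the limit of > 2510 nM in this assay, at which 1 of the 4 values shown sits. The 2,6-difluoro-4-methoxyphenyl group still does better, with a 3.2-fold higher number from compound 3 to compound 4 (0.50 log units; beyond the scatter), but that step exchanges methoxy for methyl and a fluoro for chloro together, so neither exchange can be read alone.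

Which of the methyl and the chloro in compound 4 accounts for its gain over the 2,4,6-trifluorophenyl stays open. Also open, from the compounds shown here alone, is how an ethoxy group or a dimethylamino group would fare where compound 3 carries methoxy and compound 4 carries methyl.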